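Amino for cyano in the HT-29 series

The source may report more compounds than this note shows. Statements on the series, on what has been measured and on what is new or still open speak of the compounds shown alone.

Compounds measured in a functional assay on HT-29 cells (Homo sapiens) for inhibition, read by MTT assay (a lower number here means a stronger inhibitor, a higher number a weaker inhibitor), are these:
compound 1 `COc1ccc(/C=C2\c3cc(OC)c(OC)c(OC)c3CC[C@@H]2O)cc1N` gives 160 nM
compound 2 `COc1ccc(/C=C2\c3cc(OC)c(OC)c(OC)c3CC[C@H]2O)cc1F` gives 220 nM
compound 3 `COc1ccc(/C=C2\c3cc(OC)c(OC)c(OC)c3CC[C@H]2O)cc1C#N` gives 200 nM

Compound 3 lies within the scatter of both other compounds, so the three values form one group with no order among them. The change under consideration is amino in place of cyano on an aromatic carbon, ortho to a methoxy group amino in place of cyano on an aromatic carbon and it leads to compound 4 `COc1ccc(/C=C2\c3cc(OC)c(OC)c(OC)c3CC[C@H]2O)cc1N` as the next entry. For the measured compounds named here, the one measured step at this site, cyano in place of fluoro, is small (a 1.1-fold lower number from compound 2 to compound 3 (0.04 log units; within the scatter)) and lies within the scatter. Compound 1 already carries the amino group, but with the opposite configuration at the hydroxyl carbon, and compound 1 gives 160 nM in the same read-out. Compound 4 shares its configuration with compound 2 and compound 3. Going by the values given here, no measured pair isolates the effect of that configuration, so the range is kept wide. The expected step is a 1.1-fold lower number from compound 3 to compound 4 (0.05 log units; within the scatter) in this assay and nothing beyond the scatter is anticipated. For compound 4 the estimate is 180 nM with an expected range of 80 nM to 400 nM for a single measurement.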

Compound 4, half-maximal inhibitory concentration: 910 nM
Estimate against measurement, compound 4: 5.1-fold (0.70 log units) below; measured number outside the range, above it.
By their numbers in this assay, from the lowest: compounds 1, 3 and 2 (each within the scatter of the next); then compound 4.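

In this assay, for the compounds shown here, amino at this position separates from both other groups, with a 4.6-fold higher number from compound 3 to compound 4 (0.66 log units; beyond the scatter) and a 4.1-fold higher number from compound 2 to compound 4 (0.62 log units; beyond the scatter), whereas the one earlier step at this site, a 1.1-fold lower number from compound 2 to compound 3 (0.04 log units; within the scatter), gave no sign that the substituent mattered. The configuration at the hydroxyl carbon also proves to count, and a 5.7-fold higher number from compound 1 to compound 4 (0.75 log units; beyond the scatter) in this assay can be assigned to that centre alone because of a single structural fact: the fact that compounds 1 and 4 differ only in the configuration as drawn. The amino group therefore does not set the number by itself, and with this group in place the configuration at the hydroxyl carbon decides the reading.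

The compounds shown leave open whether that configuration carries the same weight with fluoro or cyano at this position, as the only pair that isolates it has the amino group. As far as these compounds go, it is also open whether a dimethylamino or acetamido group here would follow compound 1 or compound 4 in each configuration, which would show whether the step belongs to amino alone.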